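Swapping methylsulfanyl for methyl on a hydrazone side chain

A few compounds are considered here, and "the series" means these few. Any claim that something is new, unique, unknown or untested is made for them only; others in the source may bear on it.

Measured compounds:
- compound 1 `COc1ccc2ccc(=O)oc2c1C(/C=C/c1ccc(SC)cc1)=N/NC(N)=O` gives 99 nM
- compound 2 `COc1ccc2ccc(=O)oc2c1C1=NN(C(N)=O)C(c2cccs2)C1` gives 26 nM
- compound 3 `COc1ccc2ccc(=O)oc2c1C1=NN(c2ccccc2)C(c2cccs2)C1` gives 15 nM

These three compounds were tested in a functional assay on HepG2 cells (Homo sapiens) for cytotoxicity, read by MTT assay, with a stated time of 72 h; a lower number here means a stronger inhibitor, a higher number a weaker inhibitor. Compound 1 stands at the highest number of the three: compound 2 lies a step below it that is beyond the scatter, and compound 3 lies further below still, also beyond the scatter. Between compound 2 and compound 3 the measured step is a 1.7-fold lower number from compound 2 to compound 3 (0.24 log units; within the scatter), a change on the ring nitrogen that does not touch the side chain.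

Compound 4 `COc1ccc2ccc(=O)oc2c1C(/C=C/c1ccc(C)cc1)=N/NC(N)=O` differs from compound 1 in one place: methyl in place of methylsulfanyl on an aromatic carbon. Going by the values given here, none of the measured steps involves this part of the molecule, so there is no directly relevant comparison; the one measured step concerns a different position and is within the scatter anyway. With nothing shown to favour a rise or a fall, the step from compound 1 to compound 4 is expected to be a 1.2-fold higher number from compound 1 to compound 4 (0.08 log units; within the scatter), that is, within the scatter. Compound 4 is therefore estimated at 120 nM, with a range from 50 nM to 300 nM.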

Compound 4, half-maximal inhibitory concentration: 93 nM
The estimate for compound 4 lay 1.3-fold (0.11 log units) above the measured number; low and high end bracket the measured number.
By their numbers in this assay, from the lowest: compounds 3 and 2 (each within the scatter of the next); then compounds 4 and 1 (each within the scatter of the next).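

Going by these compounds alone, the step at this position in this assay is a 1.1-fold lower number from compound 1 to compound 4 (0.03 log units; within the scatter) and gives the first measured reading for this part of the side chain. Going from 4-(methylsulfanyl)phenyl to 4-methylphenyl removes a sulfur atom and the hydrogen-bond acceptor counted for methylsulfanyl, yet compound 1 and compound 4 stay within the scatter of each other, so this exchange on the aromatic carbon shows no readable change in the number. No supporting measurement bears on why the two groups read alike.

The compounds shown leave open how this place responds to groups of a different kind, such as an amine, a carboxylic acid or a longer chain. They also leave open whether a bare hydrogen here would read like methyl and methylsulfanyl.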